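The source may hold more compounds than are shown below. What is called first, only, known or untested is meant among the compounds shown, and "the series" means these compounds.

Measured so far in a functional assay on NPC-TW01 cells (Homo sapiens) for antiproliferative activity, read by MTT assay, with a stated time of 72 h; on this read-out lower numbers stand for stronger inhibition of growth and higher numbers for weaker inhibition of growth:

- Compound 1 `O=C(COc1ccc2c(=O)cc(-c3ccccc3)oc2c1)Nc1ccccc1`: in this assay compound 1 gives > 10000 nM, which is a limit of the assay and not a number.
- Compound 2 `O=C(COc1ccc2c(=O)cc(-c3ccccc3)oc2c1)Nc1ccc(F)cc1`: compound 2 gives > 10000 nM, again only a limit.
- Compound 3 `O=C(COc1ccc2c(=O)c(-c3ccccc3)coc2c1)Nc1ccccc1`: compound 3 gives > 10000 nM, also a limit.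

The change from compound 1 to compound 2 is fluoro in place of hydrogen on an aromatic carbon. The step that the two limits leave unreadable from compound 1 to compound 2 cannot be sized because the limit of > 10000 nM in this assay, at which 3 of the 3 values shown sit, holds for both compounds. The difference between the core of compound 1 and the core of compound 3 is not broken down here.

Compound 4 `O=C(COc1ccc2c(=O)c(-c3ccccc3)coc2c1)Nc1ccc(F)cc1` is not yet measured. It differs from compound 3 by fluoro in place of hydrogen on an aromatic carbon, the same change as from compound 1 to compound 2, at the same kind of place. With every measured value sitting at the limit of > 10000 nM in this assay, at which 3 of the 3 values shown sit, the expected step is a step that the limit leaves unreadable from compound 3 to compound 4, resting on the limit of > 10000 nM in this assay, at which 3 of the 3 values shown sit, alone. Compound 4 is therefore estimated at 15000 nM, most likely reported again as a limit only.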

Compound 4, concentration for 50% growth inhibition: 550 nM
Compound 4: the middle estimate sits 27-fold (1.44 log units) above what was measured; measured number below the stated range.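

In this assay, (4-fluorophenyl)amino in place of anilino on the core of compound 3 gives an at least 18-fold lower number from compound 3 to compound 4 (1.25 log units; beyond the scatter), so on this core the change moves the result off the limit to a readable number. On the core of compound 1 the same change yields no number: compound 2 gives > 10000 nM, which is a limit of the assay. The step from compound 1 to compound 2 cannot be read, so the change is not shown to fail on that core, nor to differ there in size, and the only basis for that pair is this: the limit of > 10000 nM in this assay, at which 3 of the 4 values shown sit.

Whether the gain is specific to fluoro stays open, since the compounds shown hold no chloro, methoxy, amine or carboxylic acid at that place. The result rests on a single pair on a single core.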